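From ethoxy to ethylamino on a shared core

This account rests on a few compounds, and the source may have more. Where it says the series, first, only, none or still open, it means among the compounds named here.

In a functional assay on A2780 cells (Homo sapiens) for inhibition (a higher number here means a weaker inhibitor, a lower number a stronger inhibitor), compound 1 `CCNC(=O)c1noc(-c2cc(C(C)C)c(O)cc2O)c1-c1cc(COCC(N)=O)no1` has the entry "not determined" (no result reported), so it offers nothing to compare against. Compound 2 `CCNC(=O)c1noc(-c2cc(C(C)C)c(O)cc2O)c1-c1cc(C(=O)OCC)no1` gives 9000 nM. Among the compounds with values here, that is the only number so far, so compound 2 cannot yet be ranked against anything. Compound 3 `CCNC(=O)c1cc(-c2c(C(=O)NCC)noc2-c2cc(C(C)C)c(O)cc2O)on1` differs from compound 2 in one place: ethylamino in place of ethoxy on a carbonyl carbon. In words, ethylamino stands in place of ethoxy on a carbonyl carbon, which turns ethoxycarbonyl into ethylcarbamoyl. Within the data shown here, no measured pair shows what this swap does in this assay, so any forecast here is loose. A modest gain in inhibition is expected, with an estimated step of a 2.3-fold lower number from compound 2 to compound 3 (0.35 log units; beyond the scatter) that could still prove hard to tell from the usual scatter. For compound 3 the expected value is 4000 nM, with an estimated range from 800 nM to 15000 nM.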

Compound 3, half-maximal inhibitory concentration: 43 nM
Beside the measured number, compound 3's estimate is 93-fold (1.97 log units) above it; measured number outside the range, below it.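

With ethylamino in place of ethoxy on this carbonyl carbon, this assay shows a 210-fold lower number from compound 2 to compound 3 (2.32 log units; beyond the scatter), so this position responds strongly to the change. Both groups hold 3 heavy atoms and neither carries a net charge; the difference is that nitrogen stands where oxygen stood, adding a hydrogen-bond donor and removing a hydrogen-bond acceptor, so even an exchange that leaves the group's heavy-atom count unchanged can matter greatly here. No measurement on hand explains why the step is so large.

One pair cannot separate the role of the amide hydrogen from that of the nitrogen itself, and dimethylamino on the same carbonyl carbon would bear on that question. On these data alone, how far the effect extends also remains open, for instance with a longer chain such as butylamino or with a carboxylic acid at this position.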